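A few compounds are considered here, and "the series" means these few. Any claim that something is new, unique, unknown or untested is made for them only; others in the source may bear on it.

Measured compounds:
- compound 1 `O=C(Cn1c(=O)oc2cc(Cl)ccc21)NCc1cccs1`: 53.6%
- compound 2 `O=C(Cn1c(=O)oc2cc([N+](=O)[O-])ccc21)Nc1ccccc1`: 26.4%
- compound 3 `O=C(Cn1c(=O)oc2ccccc21)Nc1ccccc1`: 39.8%

In an ADME assay on RAW264.7 cells (Mus musculus) for cytotoxicity, read by MTT assay, with a stated time of 72 h, tested at 100 uM (on this read-out lower numbers stand for a weaker effect and higher numbers for a stronger effect at the one concentration tested), compound 2 gives the lowest of these three numbers. Compound 4 `O=C(Cn1c(=O)oc2cc([N+](=O)[O-])ccc21)NCc1cccs1` differs from it by (thiophen-2-yl)methyl in place of phenyl on an amide-type nitrogen. Going by the values given here, no measured step makes exactly this change. Among the compounds with values here, the only single-place step, a number 13.4 percentage points higher from compound 2 to compound 3 (beyond the scatter), concerns a different position. Compound 1 and compound 3 differ in this same amide group and also on the shared core; compound 1 shows 53.6% and compound 3 shows 39.8%. Taking that as a loose guide, a modest rise is expected in this assay, a number 13.6 percentage points higher from compound 2 to compound 4 (beyond the scatter). Compound 4 is therefore estimated at 40%, within a range from 24% to 56%.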

Compound 4, a percentage reported as inhibition, at one concentration (the size of the read-out at that concentration, not a potency): 41%
Compound 4: middle estimate off by 1 percentage points, on the low side, and the stated range covers the measured number.
By their numbers in this assay, from the lowest: compound 2; then compounds 3 and 4 (each within the scatter of the next); then compound 1.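

Placing (thiophen-2-yl)methyl instead of phenyl on the amide-type nitrogen, with the nitro group kept, gives a number 14.6 percentage points higher from compound 2 to compound 4 (beyond the scatter) in this assay, the first direct reading of this change. Nitro in place of chloro on an aromatic carbon gives a number 12.6 percentage points lower from compound 1 to compound 4 (beyond the scatter), a first reading of the nitro group with this amide group in place. No measurement shown explains either step. The compounds leave open whether the rise goes with the thiophene ring or with the methyl link. A benzyl group on that nitrogen would separate the two.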